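Swapping the aryl group on a cinnamide side chain

The compounds below may be only part of what the source reports. "The series", "measured", "known", "first", "only" and "open" are said of these compounds alone.

Of the compounds shown here, two have been measured in a functional assay on MCF7 cells (Homo sapiens) for cytotoxicity, read by MTT assay, with a stated time of 72 h; on this read-out lower numbers stand for stronger inhibition and higher numbers for weaker inhibition: compound 1 `CN1[C@@H]2c3[nH]c4ccccc4c3C[C@H]1[C@H](C#N)N1[C@@H](CNC(=O)c3cc4ccccc4s3)c3[nH]c4ccccc4c3C[C@@H]21` gives 3180 nM; compound 2 `CN1[C@@H]2c3[nH]c4ccccc4c3C[C@H]1[C@H](C#N)N1[C@@H](CNC(=O)/C=C/c3cccc(C(F)(F)F)c3)c3[nH]c4ccccc4c3C[C@@H]21` gives 110 nM.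

Compound 2 stands lowest of the two numbers, reached by the step of a 29-fold lower number from compound 1 to compound 2 (1.46 log units; beyond the scatter), which is large and beyond the scatter. Compound 3 `COc1ccc(/C=C/C(=O)NC[C@H]2c3[nH]c4ccccc4c3C[C@H]3[C@H]4c5[nH]c6ccccc6c5C[C@@H]([C@H](C#N)N23)N4C)cc1` differs from compound 2 by 4-methoxyphenyl in place of 3-(trifluoromethyl)phenyl on a double-bonded chain carbon bound to a double-bonded chain carbon. Among the measured compounds shown here, no measured step changes only this aryl group; the single step alters a different part of the acyl chain and shows that this region moves the number strongly, but gives no direction for the present change. Compound 3 is therefore expected to land near compound 2, at about 200 nM, within a wide range from 60 nM to 800 nM. This corresponds to an expected step of a 1.8-fold higher number from compound 2 to compound 3 (0.26 log units; within the scatter), within the scatter.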

Compound 3, half-maximal inhibitory concentration: 4220 nM
Compound 3: middle estimate off by 21-fold (1.32 log units), on the low side, outside the stated range (above it).
By their numbers in this assay, from the lowest: compound 2; then compounds 1 and 3 (each within the scatter of the next).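

On the ethenyl amide chain, the aryl group alone sets the number in this assay: 4-methoxyphenyl in place of 3-(trifluoromethyl)phenyl gives (a 38-fold higher number from compound 2 to compound 3 (1.58 log units; beyond the scatter)), so the chain by itself does not carry the low number of compound 2. With 2-(4-methoxyphenyl)ethenyl in place of 1-benzothiophen-2-yl, the change stays within the scatter (a 1.3-fold higher number from compound 1 to compound 3 (0.12 log units; within the scatter)). Nothing available accounts for this difference.

The two aryl groups differ in both substituent and ring position, and these effects remain unseparated. A 3-methoxyphenyl, a 4-(trifluoromethyl)phenyl or a plain phenyl on the same chain would address that question.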